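Chloro and methoxy pyridine sulfonamides with varied amide substituent

This account rests on a few compounds, and the source may have more. Where it says the series, first, only, none or still open, it means among the compounds named here.

Measured compounds:
compound 1 `CC(C)N1C(=O)COc2ccc(-c3cnc(Cl)c(NS(=O)(=O)c4ccc(F)cc4)c3)cc21`, 25500 nM
compound 2 `O=C1COc2ccc(-c3cnc(Cl)c(NS(=O)(=O)c4ccc(F)cc4)c3)cc2N1c1ccc(Cl)cc1`, 30600 nM
compound 3 `COc1ncc(-c2ccc3c(c2)N(c2ccc(Cl)cc2)C(=O)CO3)cc1NS(=O)(=O)c1ccc(F)cc1`, 24100 nM

All three values come from a functional assay on A-375 cells (Homo sapiens) for antiproliferative activity, read by MTT assay, with a stated time of 72 h; on this read-out higher numbers stand for weaker inhibition and lower numbers for stronger inhibition. The three numbers lie close together, and none of the steps between them goes beyond the scatter, so no order among compounds 1, 2 and 3 can be read from them.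

Compound 2 and compound 3 share everything except the group on the pyridine ring: methoxy in place of chloro on an aromatic carbon. The step of a 1.3-fold lower number from compound 2 to compound 3 (0.10 log units; within the scatter) is within the scatter.

Compound 2 and compound 1 differ at the ring amide nitrogen: isopropyl in place of 4-chlorophenyl on an amide-type nitrogen in a ring. The step of a 1.2-fold lower number from compound 2 to compound 1 (0.08 log units; within the scatter) is also within the scatter.

Compound 4 `COc1ncc(-c2ccc3c(c2)N(C(C)C)C(=O)CO3)cc1NS(=O)(=O)c1ccc(F)cc1` is not yet measured in this assay. It differs from compound 3 by isopropyl in place of 4-chlorophenyl on an amide-type nitrogen in a ring. This is the same change as the one from compound 2 to compound 1, and it appears twice among these compounds; the place is described in the same words in both cases.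

The expectation for compound 4 therefore rests on compound 3, whose value is 24100 nM, and on the earlier step of a 1.2-fold lower number from compound 2 to compound 1 (0.08 log units; within the scatter), which stayed within the scatter. A step of similar size, a 1.2-fold lower number from compound 3 to compound 4 (0.08 log units; within the scatter), is expected in this assay for compound 4. Compound 4 is accordingly estimated at 20000 nM, with a range from 9000 nM to 45000 nM in this assay.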

Compound 4, half-maximal inhibitory concentration: 9950 nM
Beside the measured number, compound 4's estimate is 2.0-fold (0.30 log units) above it, and the stated range covers the measured number.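

In this assay, isopropyl in place of 4-chlorophenyl on the ring amide nitrogen gives a 2.4-fold lower number from compound 3 to compound 4 (0.38 log units; beyond the scatter) when methoxy sits on the aromatic carbon, and the comparison with the chloro pair shows no difference in this change between the two cores: the same change on two cores in this assay, a 1.2-fold lower number (0.08 log units; within the scatter) from compound 2 to compound 1 and a 2.4-fold lower number (0.38 log units; beyond the scatter) from compound 3 to compound 4, 2.0-fold (0.31 log units) apart, within the scatter of two such steps

Methoxy in place of chloro gives a 2.6-fold lower number from compound 1 to compound 4 (0.41 log units; beyond the scatter) when isopropyl sits on the amide nitrogen, and this change likewise carries from one core to the other without a difference beyond the scatter: the same change on two cores in this assay, a 1.3-fold lower number (0.10 log units; within the scatter) from compound 2 to compound 3 and a 2.6-fold lower number (0.41 log units; beyond the scatter) from compound 1 to compound 4, 2.0-fold (0.31 log units) apart, within the scatter of two such steps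

Going by these compounds alone, each change therefore transfers within what these data can resolve, but with only two cores per change this does not show that the step has a fixed size, nor that the two changes add up, and it gives no reason why only the steps into compound 4 pass beyond the scatter.

Still open, from the compounds shown here alone, is whether the same behaviour holds for other groups on the amide nitrogen, such as cyclopropyl, a longer alkyl chain or a chain ending in an amine. Also open, going by these compounds, is how a nitrile or a methyl group in place of methoxy or chloro on the aromatic carbon would behave, and whether either change carries over to a core with another sulfonamide aryl group.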